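Amino to iodo: a step with only limits to guide it

The source may hold more compounds than are shown below. What is called first, only, known or untested is meant among the compounds shown, and "the series" means these compounds.

Compound 1 `O=C(/C=C/c1ccc2c(c1)B(O)OC2)c1ccc(C(F)(F)F)cc1` and compound 2 `Nc1ccc(C(=O)/C=C/c2ccc3c(c2)B(O)OC3)cc1` share one core and were both run in an ADME assay on L929 cells (Mus musculus) for cytotoxicity, read by resazurin assay, with a stated time of 72 h; on this read-out higher numbers stand for weaker inhibition and lower numbers for stronger inhibition. Compound 1 gives > 10 ug/mL, which is a limit and not a number. Compound 2 gives > 10 ug/mL, also a limit. Going by the values given here, the only measured step, a step that the two limits leave unreadable from compound 1 to compound 2, therefore has no usable size, and the limit of > 10 ug/mL in this assay, at which 2 of the 2 values shown sit, is all the evidence there is. Compound 3 `O=C(/C=C/c1ccc2c(c1)B(O)OC2)c1ccc(I)cc1` differs from compound 2 by iodo in place of amino on an aromatic carbon. No change beyond the scatter is expected in this assay, and the estimated step is a step that the limit leaves unreadable from compound 2 to compound 3. For compound 3 the expected value is 15 ug/mL, with an estimated range from 5 ug/mL to 40 ug/mL.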

Compound 3, half-maximal inhibitory concentration: > 10 ug/mL
Compound 3: a limit, no number; the forecaster's own chance of this, stated with the estimate: 70%; the middle value does not contradict the limit.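

In this assay no step can be read among compound 1, compound 2 and compound 3, since each gives a limit and not a number: the limit of > 10 ug/mL in this assay, at which 3 of the 3 values shown sit.

The compounds shown leave open whether trifluoromethyl, amino and iodo differ at all in their effect on cytotoxicity.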